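The compounds below may be only part of what the source reports. "The series", "measured", "known", "first", "only" and "open" are said of these compounds alone.

Working notes on the series. Compound 1 `COc1cc(C2CC(c3ccccc3)=NN2C(=O)OCc2ccccc2)cc(OC)c1OC` carries the shared core with a phenyl. In a functional assay on A2780 cells (Homo sapiens) for antiproliferative activity, read by MTT assay, with a stated time of 48 h (on this read-out higher numbers stand for weaker inhibition of growth and lower numbers for stronger inhibition of growth), compound 1 reaches only the limit of the measurement, > 10000 nM. Compound 2 `COc1ccc(C2=NN(C(=O)OCc3ccccc3)C(c3cc(OC)c(OC)c(OC)c3)C2)cc1` differs from compound 1 by methoxy in place of hydrogen on an aromatic carbon. In this assay compound 2 likewise gives only a limit, > 10000 nM. The step that the two limits leave unreadable from compound 1 to compound 2 therefore cannot be read, because the limit of > 10000 nM in this assay, at which 3 of the 3 values shown sit, covers both ends of it.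

Compound 3 `COC(=O)N1N=C(c2ccccc2)CC1c1ccc(OC)cc1` has a different core; the difference between the two cores is not broken down here. In this assay compound 3 again sits at a limit, > 10000 nM.

Compound 4 `COC(=O)N1N=C(c2ccccc2)CC1c1ccc(OC)c(OC)c1`, not yet measured, differs from compound 3 by methoxy in place of hydrogen on an aromatic carbon. Within the data shown here, this is the same kind of change as the one from compound 1 to compound 2, but the surroundings differ: in compound 2 the entering methoxy sits para to a large group, in compound 4 it sits ortho to a methoxy group and meta to a large group. With every measured value at a limit, the step from compound 3 to compound 4 is expected to be small, a step that the limit leaves unreadable from compound 3 to compound 4, resting only on the fact that the earlier step of this kind was unreadable. Compound 4 is estimated in this assay at 12000 nM, with a range from 3000 nM to 40000 nM, most likely again reported only as a limit.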

Compound 4, concentration for 50% growth inhibition: 29900 nM
Beside the measured number, compound 4's estimate is 2.5-fold (0.40 log units) below it; low and high end bracket the measured number.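

In this assay the step from compound 3 to compound 4 cannot be read, because compound 3 gives only a limit: the limit of > 10000 nM in this assay, at which 3 of the 4 values shown sit.

The compounds shown leave open whether methoxy in place of hydrogen on an aromatic carbon changes growth inhibition at all, on either core.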